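A few compounds are considered here, and "the series" means these few. Any claim that something is new, unique, unknown or untested is made for them only; others in the source may bear on it.

Compound 1 `Cc1cccc(NNC(=O)c2ccc(NS(=O)(=O)c3cnc(O)nc3O)cc2)c1` is tested in a functional assay on SGC-7901 cells (Homo sapiens) for antiproliferative activity, read by MTT assay, with a stated time of 24 h (a higher number here means a weaker inhibitor, a lower number a stronger inhibitor), and there compound 1 gives only a limit of the assay, > 20000 nM. Compound 2 `Cc1cccc(NNC(=O)c2cccc(NS(=O)(=O)c3cnc(O)nc3O)c2)c1` likewise reaches only a limit in this assay, > 20000 nM. Compound 3 `O=C(NNc1ccccc1Cl)c1ccccc1NS(=O)(=O)c1cnc(O)nc1O` also returns a limit in this assay, > 20000 nM. Compound 1 therefore stands nowhere distinct among the numbers shown: every value sits at the limit of > 20000 nM in this assay, at which 3 of the 3 values shown sit, and no step between measured compounds can be read from them, since none of the three is a number.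

Compound 4 `O=C(NNC(=O)c1ccccc1F)c1ccc(NS(=O)(=O)c2cnc(O)nc2O)cc1` is not yet measured. It differs from compound 1 in one place on the shared core ((2-fluorophenyl)carbonyl in place of 3-methylphenyl on an amine nitrogen), so that the (3-methylphenyl)amino of compound 1 becomes a ((2-fluorophenyl)carbonyl)amino. With every measured compound at the limit, no direction for this change is supported by the data, and the step from compound 1 to compound 4 is expected as a number no higher from compound 1 to compound 4 (the limit leaves the size open), nothing beyond the scatter. Compound 4 is accordingly estimated at 20000 nM, within 5000 nM to 60000 nM, and most likely it too will return only a limit.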

Compound 4, half-maximal inhibitory concentration: > 20000 nM
Compound 4: a limit, no number (the forecaster's own chance of this, stated with the estimate: 75%); the middle value sits exactly at the limit.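

Going by these compounds alone, compound 1 and compound 4 each return only a limit in this assay, so no step between them can be read. The compounds shown leave open which change on the shared core, if any, would yield a readable number, since all remain at the limit: the limit of > 20000 nM in this assay, at which 4 of the 4 values shown sit.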